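Cyclopropyl on the Amide Nitrogen of a Brominated Acrylamide

A few compounds are considered here, and "the series" means these few. Any claim that something is new, unique, unknown or untested is made for them only; others in the source may bear on it.

Compound 2 `NC(=O)/C=C1\CCc2ccc(Br)cc21` gives 100% in a functional assay on the whole organism with Mus musculus as the target, at a dose of 100 mg/kg by the intraperitoneal route (on this read-out higher numbers stand for more inhibition at the one dose given (going by the name of the read-out) and lower numbers for less inhibition), level with compound 1 `NC(=O)/C=C1\CCc2c(F)cc(F)cc21`, which gives 100%; together they are the highest of the three numbers. For the measured compounds named here, compound 3 `Cc1ccc2c(c1)/C(=C/C(N)=O)CC2` gives 33%, and a number 67 percentage points lower from compound 2 to compound 3 (beyond the scatter) is the only measured step, a methyl in place of bromo on an aromatic carbon. Compound 4 `O=C(/C=C1\CCc2ccc(Br)cc21)NC1CC1` differs from compound 2 by cyclopropyl in place of hydrogen on an amide-type nitrogen. No measured step touches that amide-type nitrogen, so the step from compound 2 to compound 3 does not bear directly on it, and the size expected for a number 40 percentage points lower from compound 2 to compound 4 (beyond the scatter) rests on no shown pair and is uncertain in direction. Compound 4 is therefore expected to give 60%, within 10% to 100%.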

Compound 4, a percentage reported as inhibition, in the whole organism at one dose (the size of the read-out at that dose, not a potency): 33%
The estimate for compound 4 lay 27 percentage points above the measured number; measured number inside the range.
By their numbers in this assay, from the lowest: compounds 3 and 4 (each within the scatter of the next); then compounds 1 and 2 (each within the scatter of the next).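

The amide-type nitrogen had not been touched by any earlier step, and in this assay it proves sensitive to substitution: with the bromo kept, cyclopropyl in place of hydrogen gives a number 67 percentage points lower from compound 2 to compound 4 (beyond the scatter). The change at this nitrogen alone is therefore enough to cost a large part of the read-out at the one dose given. Nothing available accounts for this drop. From the compounds shown here alone, whether an ethyl or a hydroxyethyl chain on the same nitrogen would cost as much remains open. So does whether cyclopropyl would do the same on the difluoro compound 1.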